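The source may report more compounds than this note shows. Statements on the series, on what has been measured and on what is new or still open speak of the compounds shown alone.

Compound 1 `COc1cc(/C=C/C(=O)c2cccc(NC(=O)c3ccco3)c2)ccc1O` carries a (furan-2-yl)carbonyl on its amide nitrogen and is tested in a functional assay on SiHa cells (Homo sapiens) for inhibition (a lower number here means a stronger inhibitor, a higher number a weaker inhibitor), where compound 1 gives 0.76 ug/mL. Among the three measured compounds this is the lowest number: the nearest is compound 3 `COc1cc(/C=C/C(=O)c2cccc(NC(=O)c3c(Cl)cccc3Cl)c2)ccc1O`, which in this assay gives 3.56 ug/mL, and the furthest is compound 2 `COc1cc(/C=C/C(=O)c2cccc(NC(=O)c3cccs3)c2)ccc1O`, which gives 6.57 ug/mL.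

Compound 4 `COc1cc(/C=C/C(=O)c2cccc(NC(=O)c3ccc(Cl)cc3)c2)ccc1O` differs from compound 1 in one place: 4-chlorophenyl in place of furan-2-yl on a carbonyl carbon.

Among the measured compounds shown here, two measured steps bear on this change, since both also swap the furan-2-yl on the carbonyl carbon for another aromatic ring. In this assay there is an 8.6-fold higher number from compound 1 to compound 2 (0.94 log units; beyond the scatter) and a 4.7-fold higher number from compound 1 to compound 3 (0.67 log units; beyond the scatter). Both swaps gave a higher number, and the step from compound 2 to compound 3, a 1.8-fold lower number from compound 2 to compound 3 (0.27 log units; within the scatter), shows that the two replacements did not differ much from each other. Compound 4 introduces a six-membered ring of carbon only, as compound 3 does, so a modestly higher number than compound 1 is expected, roughly in the range spanned by compound 2 and compound 3. The expected step is a 4.6-fold higher number from compound 1 to compound 4 (0.66 log units; beyond the scatter). Compound 4 is therefore estimated at 3.5 ug/mL in this assay, with a range from 1.2 ug/mL to 9 ug/mL.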

Compound 4, half-maximal inhibitory concentration: 2.3 ug/mL
Beside the measured number, compound 4's estimate is 1.5-fold (0.18 log units) above it; the measured number falls inside the stated range.
By their numbers in this assay, from the lowest: compound 1; then compounds 4, 3 and 2 (each within the scatter of the next, the first and the last beyond it).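

In this assay, a 3.0-fold higher number from compound 1 to compound 4 (0.48 log units; beyond the scatter), so 4-chlorophenyl joins thiophen-2-yl and 2,6-dichlorophenyl as a third replacement on this carbonyl carbon that gives a higher number than the furan-2-yl group of compound 1. The two chlorine-bearing rings cannot be told apart, as a 1.5-fold lower number from compound 3 to compound 4 (0.19 log units; within the scatter) lies within the scatter, and the change from 2,6-dichlorophenyl to 4-chlorophenyl therefore has no readable effect in this series. The replacements are not all equivalent, however: a 2.9-fold lower number from compound 2 to compound 4 (0.46 log units; beyond the scatter) lies beyond the scatter, which separates thiophen-2-yl from 4-chlorophenyl, even though the earlier step between thiophen-2-yl and 2,6-dichlorophenyl stayed within it.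

Nothing in the data given explains why these groups differ. From the compounds shown here alone, it also remains open whether the low number of compound 1 is specific to the furan-2-yl ring, a question that could be tested on the same carbonyl carbon with a furan-3-yl group, a 5-methylfuran-2-yl group, a pyridin-2-yl ring or an open chain such as propyl.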